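A few compounds are considered here, and "the series" means these few. Any claim that something is new, unique, unknown or untested is made for them only; others in the source may bear on it.

Compound 1 `COc1cc(/C=C2\CN(C)C/C(=C\c3cccc([N+](=O)[O-])c3)C2=O)cc(OC)c1` opens the series. In a functional assay on K562 cells (Homo sapiens) for cytotoxicity, read by MTT assay, with a stated time of 24 h (a higher number here means a weaker inhibitor, a lower number a stronger inhibitor), compound 1 gives 4420 nM. Compound 2 `COc1cc(/C=C2\CN(C)C/C(=C\c3ccc(C#N)cc3)C2=O)cc(OC)c1` carries the change 4-cyanophenyl in place of 3-nitrophenyl on a double-bonded chain carbon bound to a double-bonded ring carbon and in this assay compound 2 gives 4650 nM, so the step of a 1.1-fold higher number from compound 1 to compound 2 (0.02 log units; within the scatter) is small. Compound 3 `COc1cc(/C=C2\CN(C)C/C(=C\c3cccc([N+](=O)[O-])c3)C2=O)cc(OC)c1OC` has a core that differs from the core of compound 1 by methoxy in place of hydrogen on an aromatic carbon; in this assay compound 3 gives 4200 nM, and the step of a 1.1-fold lower number from compound 1 to compound 3 (0.02 log units; within the scatter) is likewise small. Compound 4 `COc1cc(/C=C2\CN(C)C/C(=C\c3ccc(C#N)cc3)C2=O)cc(OC)c1OC` has not yet been measured. It arises from compound 3 through (4-cyanophenyl in place of 3-nitrophenyl on a double-bonded chain carbon bound to a double-bonded ring carbon), the same change that links compound 1 to compound 2, now made on the core of compound 3 described above. Because the step of a 1.1-fold higher number from compound 1 to compound 2 (0.02 log units; within the scatter) stayed within the scatter, the step of a 1.1-fold higher number from compound 3 to compound 4 (0.03 log units; within the scatter) is expected to be of similar size. Compound 4 is therefore estimated at 4450 nM, with a likely range from 2500 nM to 8000 nM.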

Compound 4, half-maximal inhibitory concentration: 4290 nM
Estimate against measurement, compound 4: 1.0-fold (0.02 log units) above, within the range that was stated.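

In this assay, the change to 4-cyanophenyl on the core of compound 3 gives a 1.0-fold higher number from compound 3 to compound 4 (0.01 log units; within the scatter), and the step is as small there as on the core of compound 1: the same change on two cores in this assay, a 1.1-fold higher number (0.02 log units; within the scatter) from compound 1 to compound 2 and a 1.0-fold higher number (0.01 log units; within the scatter) from compound 3 to compound 4, 1.0-fold (0.01 log units) apart, within the scatter of two such steps The added methoxy, read on the cyano pair, gives a 1.1-fold lower number from compound 2 to compound 4 (0.03 log units; within the scatter), and it too carries over between the two cores: the same change on two cores in this assay, a 1.1-fold lower number (0.02 log units; within the scatter) from compound 1 to compound 3 and a 1.1-fold lower number (0.03 log units; within the scatter) from compound 2 to compound 4, 1.0-fold (0.01 log units) apart, within the scatter of two such steps This shows that both changes stay within the scatter on either core, but since all four steps are small, it does not show that a step of real size would carry over in the same way.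

The compounds shown leave open whether an amine or a carboxylic acid in place of the 3-nitrophenyl or 4-cyanophenyl substituent would move the number beyond the scatter. They also leave open whether a longer chain in place of a methoxy would do so.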